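A few compounds are considered here, and "the series" means these few. Any claim that something is new, unique, unknown or untested is made for them only; others in the source may bear on it.

Of the compounds shown here, three built on one shared core have been measured in a functional assay on HepG2 cells (Homo sapiens) for inhibition, read by MTT assay, with a stated time of 72 h; a higher number here means a weaker inhibitor, a lower number a stronger inhibitor. Compound 1 `Cc1nc(N(C)C(=O)NC(=O)c2c(F)cccc2F)sc1C(=O)N/N=C/c1cccc(C(F)(F)F)c1` gives 31.6 ug/mL. Compound 2 `Cc1nc(N(C)C(=O)NC(=O)c2c(F)cccc2F)sc1C(=O)N/N=C/c1ccccc1` gives 54.3 ug/mL. Compound 3 `Cc1nc(N(C)C(=O)NC(=O)c2c(F)cccc2F)sc1C(=O)N/N=C/c1ccc(Cl)cc1Cl` gives 70 ug/mL, the highest of the three numbers; its gap to compound 2 lies within the scatter, while the step of a 2.2-fold higher number from compound 1 to compound 3 (0.35 log units; beyond the scatter) is modest but beyond it. The step of a 1.3-fold higher number from compound 2 to compound 3 (0.11 log units; within the scatter) stays within the scatter.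

Compound 4 `Cc1nc(N(C)C(=O)NC(=O)c2c(F)cccc2F)sc1C(=O)N/N=C/c1ccccc1C(F)(F)F` has not yet been measured. It differs from compound 3 in one place: 2-(trifluoromethyl)phenyl in place of 2,4-dichlorophenyl on a carbon with a double bond to nitrogen. Within the data shown here, two measured steps bear on this change. The step of a 2.2-fold higher number from compound 1 to compound 3 (0.35 log units; beyond the scatter) shows how a 3-(trifluoromethyl)phenyl on that carbon compares with the 2,4-dichlorophenyl, and the step of a 1.3-fold higher number from compound 2 to compound 3 (0.11 log units; within the scatter) shows that the 2,4-dichlorophenyl differs little from a bare phenyl. Compound 4 carries a trifluoromethyl-bearing ring again, though as 2-(trifluoromethyl)phenyl rather than 3-(trifluoromethyl)phenyl, and nothing measured tells whether those two behave alike. Reversing the step from compound 1 to compound 3 would lower the number modestly; the step from compound 2 to compound 3 points to no change beyond the scatter. Compound 4 is therefore expected to show the step of a 1.7-fold lower number from compound 3 to compound 4 (0.22 log units; within the scatter), a modest lowering. The estimate for compound 4 in this assay is 42 ug/mL, with a range from 20 ug/mL to 85 ug/mL.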

Compound 4, half-maximal inhibitory concentration: 1.11 ug/mL
Compound 4: the middle estimate sits 38-fold (1.58 log units) above what was measured; the measured number lies below the stated range.
By their numbers in this assay, from the lowest: compound 4; then compounds 1, 2 and 3 (each within the scatter of the next, the first and the last beyond it).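

In this assay, among these compounds, the step of a 28-fold lower number from compound 1 to compound 4 (1.45 log units; beyond the scatter) answers what the earlier compounds could not: on a carbon with a double bond to nitrogen, 2-(trifluoromethyl)phenyl and 3-(trifluoromethyl)phenyl are far from interchangeable. Until now, changes at this place had moved the number only a little or modestly, but the steps of a 49-fold lower number from compound 2 to compound 4 (1.69 log units; beyond the scatter) and a 63-fold lower number from compound 3 to compound 4 (1.80 log units; beyond the scatter) show that the same place can carry a large change, and compound 4 now stands apart as the strongest inhibitor of the four, while the 2,4-dichlorophenyl of compound 3 gives no such gain. Nothing available here accounts for why this one ring behaves so differently from the other three.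

On these data alone, it remains open whether the trifluoromethyl group itself is needed for the low number of compound 4, or whether a 2-methylphenyl or 2-methoxyphenyl ring on that carbon would give a similar result. As far as these compounds go, it is also open whether the gain would persist if the rest of the shared core were changed, for instance with an amine in place of the methyl group on the urea nitrogen.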